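Series notes: aryl exchange on the shared core, compound 3

The compounds below may be only part of what the source reports. "The series", "measured", "known", "first", "only" and "open" are said of these compounds alone.

Compound 2 `Cc1cc(-c2nc(C(c3ccc(F)cc3)c3ccc(F)cc3)sc2CC(=O)O)cnc1N` gives 80% in an in vitro functional assay on HEK285-7 cells for antagonist activity at prostaglandin D2 receptor 2 (Homo sapiens), read by BRET and beta-arrestin recruitment (on this read-out lower numbers stand for smaller maximal responses and higher numbers for larger maximal responses), and stands level with compound 1 `O=C(O)Cc1sc(C(c2ccc(F)cc2)c2ccc(F)cc2)nc1-c1cc(F)nc(F)c1`, which gives 80%; the step of no change at the digits printed from compound 1 to compound 2 (within the scatter) lay within the scatter. Compound 3 `O=C(O)Cc1sc(C(c2ccc(F)cc2)c2ccc(F)cc2)nc1-c1ccnc(N2CCC2)c1` differs from compound 2 by 2-(azetidin-1-yl)pyridin-4-yl in place of 6-amino-5-methylpyridin-3-yl on an aromatic carbon. Among the compounds with values here, the only measured step that bears on this exchange of the aromatic group at the same place, no change at the digits printed from compound 1 to compound 2 (within the scatter), left the maximal response unchanged. On that basis the estimated step of no change at the digits printed from compound 2 to compound 3 (within the scatter) is expected to stay within the scatter. Compound 3 is therefore expected at 80%, with a range of 65% to 95%.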

Compound 3, largest response reached (reported as efficacy), in percent of the reference or control that the assay uses: 80%
Compound 3: middle estimate and measured number agree at the digits printed; measured number inside the range.
By their numbers in this assay, from the lowest: compounds 1, 2 and 3 (each within the scatter of the next).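

In this assay, the aromatic carbon next to the ring nitrogen now carries a 2-(azetidin-1-yl)pyridin-4-yl group, which brings a four-membered non-aromatic ring and no hydrogen-bond donor (no change at the digits printed from compound 2 to compound 3 (within the scatter)). Against the 2,6-difluoropyridin-4-yl group the picture is the same (no change at the digits printed from compound 1 to compound 3 (within the scatter)). No measurement available here accounts for this flat read-out.

Open, on these data alone, is whether any group at this position moves the maximal response beyond the scatter. A phenyl ring bearing a carboxylic acid or a longer amine chain would test this.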